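Removing the Cyano Group: What to Expect for Compound 4

The source may hold more compounds than are shown below. What is called first, only, known or untested is meant among the compounds shown, and "the series" means these compounds.

Of the compounds shown here, three have been measured in a functional assay on L1210 cells (Mus musculus) for antiproliferative activity; a higher number here means a more potent compound, by a factor of ten per unit of this negative logarithm, a lower number a less potent compound. Compound 1, `CC(C)N(C)/N=N/c1ccc(C(N)=O)cc1`, gives 3.17. Compound 2, `CN(C)/N=N/c1ccc(C#N)cc1C(N)=O`, gives 3.46. Compound 3, `CN(Cc1ccccc1)/N=N/c1nc[nH]c1C(N)=O`, gives 3.43.

Compound 2 has the highest of the three values, but its gaps to compound 3 and to compound 1 both lie within the usual scatter, so the three cannot be told apart on these numbers. Compound 4, `CN(C)/N=N/c1ccccc1C(N)=O`, has not been measured. It arises from compound 2 by one change: hydrogen in place of cyano on an aromatic carbon. For the measured compounds named here, no two measured compounds differ in a single place, so there is no measured step to lean on. The values of compound 1, 3.17, and of compound 3, 3.43, sit close to that of compound 2 despite several differences, so this single change is expected to leave the number near where it is. The step in this assay is expected to be a number 0.16 log units lower from compound 2 to compound 4 (within the scatter), within the scatter. Compound 4 is expected to give about 3.3, between 2.9 and 3.7.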

Compound 4, logarithm of the reciprocal of the active concentration, log(1/C): 3.31
Beside the measured number, compound 4's estimate is 0.01 log units below it, and the stated range covers the measured number.
By their numbers in this assay, from the lowest: compounds 1, 4, 3 and 2 (each within the scatter of the next).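

For the compounds shown here, for the first time, a pair of compounds differs in one place only, so a single change can be read directly: in this assay the step is a number 0.15 log units lower from compound 2 to compound 4 (within the scatter) with hydrogen in place of cyano on an aromatic carbon. At this place, meta to a carbamoyl group and para to a group of 5 heavy atoms, the nitrile is therefore not needed for the number to stay at this level.

The compounds shown leave open whether another group at the same place, such as an amine, a carboxylic acid or a methoxy group, would also leave the number within the usual scatter, and whether this same swap would do so on a different core. Nothing measured here offers a reason for this result.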